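The compounds below may be only part of what the source reports. "The series", "measured", "known", "first", "only" and "open" are said of these compounds alone.

Measured in a functional assay on HCT-116 cells (Homo sapiens) for inhibition, read by CCK-8 assay, with a stated time of 72 h, tested at 8 uM; on this read-out higher numbers stand for more inhibition of growth at the one concentration tested and lower numbers for less inhibition of growth:
compound 1 `CCc1ccc(SCc2ccc(C(=O)Nc3ccccc3N)cc2)cc1`: 79.1%
compound 2 `Cc1ccc(SCc2ccc(C(=O)Nc3ccccc3N)cc2)cc1`: 84%
compound 3 `Nc1ccccc1NC(=O)c1ccc(CSc2ccc(Br)cc2)cc1`: 67.7%

Compound 3, at 67.7%, is the lowest of the three in this assay, and compound 1 and compound 2 both lie beyond the scatter above it.

Next in the series is compound 4 `CC(C)(C)c1ccc(SCc2ccc(C(=O)Nc3ccccc3N)cc2)cc1`. The change is tert-butyl in place of bromo on an aromatic carbon, para to a large group.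

Going by the values given here, two measured steps bear on this, both read in reverse. With bromo in place of methyl, the change is a number 16.3 percentage points lower from compound 2 to compound 3 (beyond the scatter). With bromo in place of ethyl, it is a number 11.4 percentage points lower from compound 1 to compound 3 (beyond the scatter). Methyl and ethyl themselves are not separated, as the change is a number 4.9 percentage points higher from compound 1 to compound 2 (within the scatter).

Among the compounds with values here, these are only two comparisons, and no branched group has been measured at this place, so the carry-over to tert-butyl is uncertain. An upward step is expected, smaller than those two and possibly not clear of the scatter. The expected change is a number 8.3 percentage points higher from compound 3 to compound 4 (within the scatter).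

Compound 4 is estimated at 76%, with an expected range of 62% to 88%.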

Compound 4, percent growth inhibition at one concentration: 60.5%
The estimate for compound 4 lay 15.5 percentage points above the measured number; measured number outside the range, below it.
By their numbers in this assay, from the lowest: compounds 4 and 3 (each within the scatter of the next); then compounds 1 and 2 (each within the scatter of the next).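

In this assay, going by these compounds alone, the step of a number 23.5 percentage points lower from compound 2 to compound 4 (beyond the scatter) and the step of a number 18.6 percentage points lower from compound 1 to compound 4 (beyond the scatter) show that tert-butyl, the first branched group at this position, does not stay with methyl and ethyl, which the earlier compounds had left unseparated. The step of a number 7.2 percentage points lower from compound 3 to compound 4 (within the scatter) leaves tert-butyl and bromo unseparated, so the four groups fall into two sets on this read-out, with compound 3 and compound 4 lying beyond the scatter under compound 1 and compound 2, even though bromo counts a single heavy atom and tert-butyl four. No measurement is available here that explains why these groups divide in this way.

From the compounds shown here alone, whether isopropyl would stay with methyl and ethyl or fall with bromo and tert-butyl remains open, and this would help show whether the branching itself or simply the larger group goes with the lower numbers. Also open, going by these compounds, is where a chloro group, a methoxy group, an amine or a carboxylic acid would fall at this place on the same read-out.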